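Aryl thiosemicarbazone isatin series: cytotoxicity on HeLa cells

The source may hold more compounds than are shown below. What is called first, only, known or untested is meant among the compounds shown, and "the series" means these compounds.

Measured compounds:
- Compound 1, `CCN(CC)CN1C(=O)/C(=N/NC(=S)Nc2ccccc2)c2cc(Cl)ccc21`. In an ADME assay on HeLa cells (Homo sapiens) for cytotoxicity (a higher number here means that more compound is tolerated, a lower number that less compound is tolerated), compound 1 gives >= 20000 nM, which is a limit of the assay, not a number.
- Compound 2, `CCN(CC)CN1C(=O)/C(=N/NC(=S)Nc2ccc(Cl)cc2)c2ccccc21`. In this assay compound 2 gives >= 4000 nM, again a limit.
- Compound 3, `CCN(CC)CN1C(=O)/C(=N/NC(=S)Nc2ccc(OC)cc2)c2ccccc21`. In this assay compound 3 gives >= 4000 nM, also a limit.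

Compound 3 thus stands at a limit, and the two further values shown are limits as well: two of the three sit at the limit of >= 4000 nM in this assay, at which 2 of the 3 values shown sit, one at the limit of >= 20000 nM in this assay, at which 1 of the 3 values shown sits. Within the data shown here, the one step between neighbours, a step that the two limits leave unreadable from compound 2 to compound 3, cannot be read for size since both ends are limits.

Compound 4, `CCN(CC)CN1C(=O)/C(=N/NC(=S)Nc2ccccc2)c2ccccc21`, is not yet measured. It differs from compound 3 by hydrogen in place of methoxy on an aromatic carbon. Among the measured compounds shown here, no measured step bears on this change, as the only neighbouring step is unreadable. Given that compound 3 gives only a limit, the step that the limit leaves unreadable from compound 3 to compound 4 is expected to be small or unreadable, with no direction claimed. Compound 4 is estimated at 8000 nM, between 3000 nM and 30000 nM, most likely again reported as a limit.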

Compound 4, minimum cytotoxic concentration: >= 20000 nM
Compound 4 was reported as a limit (the forecaster's own chance of this, stated with the estimate: 85%); middle value at least 2.5-fold (0.39 log units) from the limit.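

Compound 4 is reported only as a limit in this assay, as are compound 1, compound 2 and compound 3, so no step among these compounds can be read. The compounds shown leave open whether hydrogen, chloro or methoxy on the aromatic carbon changes the concentration tolerated in this assay.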